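This account rests on a few compounds, and the source may have more. Where it says the series, first, only, none or still open, it means among the compounds named here.

Compound 1 `NC1CCc2nc(-c3ccncc3)nc(Nc3cccc(F)c3)c2C1` is drawn without a set configuration at the stereocentre on its saturated ring; in a functional assay on DU-145 cells (Homo sapiens) for antiproliferative activity, read by MTT assay, with a stated time of 72 h (on this read-out lower numbers stand for stronger inhibition and higher numbers for weaker inhibition), compound 1 gives 15100 nM. Compound 2 `N[C@@H]1CCc2nc(-c3ccncc3)nc(Nc3cccc(F)c3)c2C1` carries the same atoms with that centre drawn R, and in this assay compound 2 gives 11100 nM, the lower of the two numbers shown, a gap within the scatter. Within the data shown here, the only measured step, a 1.4-fold lower number from compound 1 to compound 2 (0.13 log units; within the scatter), rests on (the fact that one of compounds 1 and 2 is drawn with a defined configuration and the other without, at the place where they differ). Compound 3 `N[C@H]1CCc2nc(-c3ccncc3)nc(Nc3cccc(F)c3)c2C1` differs from compound 2 in one way: the two compounds have the same atoms and bonds and differ only in configuration as drawn: 1 of 1 stereo elements differ; a stereocentre at a saturated ring carbon is drawn R in compound 2 and S in compound 3. Among the measured compounds shown here, no measured step compares the two configurations directly, so the step of a 2.0-fold higher number from compound 2 to compound 3 (0.30 log units; within the scatter) is expected to be modest, leaning toward a higher number. Compound 3 is estimated at 22000 nM, between 8000 nM and 60000 nM.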

Compound 3, half-maximal inhibitory concentration: 17900 nM
Compound 3: the middle estimate sits 1.2-fold (0.09 log units) above what was measured, within the range that was stated.
By their numbers in this assay, from the lowest: compounds 2, 1 and 3 (each within the scatter of the next).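

With both configurations now drawn, the direct comparison in this assay is a 1.6-fold higher number from compound 2 to compound 3 (0.21 log units; within the scatter), so exchanging R for S at this saturated ring carbon gives no difference that these numbers can resolve. The compound drawn without a configuration fits the same picture, with a 1.2-fold higher number from compound 1 to compound 3 (0.07 log units; within the scatter). This reading of the position is a clean one, as only one thing changes: the fact that compounds 2 and 3 differ only in the configuration as drawn

All three compounds carry the same amine at this ring carbon. As far as these compounds go, whether a hydroxyl group or a carboxylic acid there would give a different number, in either configuration, stays open.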